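Shortening a Chain Beside the Ring Nitrogen

The source may hold more compounds than are shown below. What is called first, only, known or untested is meant among the compounds shown, and "the series" means these compounds.

Measured so far:
Compound 1, `CCCCn1ncnc1-c1ccccc1NCC1=NCCN1`: 66%
Compound 2, `Cn1ncnc1-c1ccccc1NCC1=NCCN1`: 116%

Compound 2 stands highest of the two numbers in a functional assay with Alpha-1D adrenergic receptor (Homo sapiens) as the target, read by calcium flux; a higher number here means a larger maximal response, a lower number a smaller maximal response; its nearest neighbour, compound 1, sits a good distance below, and the step of a number 50 percentage points higher from compound 1 to compound 2 (beyond the scatter) is well beyond the usual scatter. Compound 3, `CCCn1ncnc1-c1ccccc1NCC1=NCCN1`, is not yet measured. It differs from compound 2 in one place, (ethyl in place of hydrogen on a saturated chain carbon bound to an aromatic nitrogen). For the measured compounds named here, the only measured step that bears on this is a number 50 percentage points higher from compound 1 to compound 2 (beyond the scatter), which runs in the opposite direction and covers a longer chain. The change to compound 3 goes part of the way back toward compound 1, so a fall in this assay is expected, smaller than the step seen between compound 1 and compound 2 because a number 50 percentage points higher from compound 1 to compound 2 (beyond the scatter) covered a larger change. For compound 3 the estimated step is a number 31 percentage points lower from compound 2 to compound 3 (beyond the scatter). Compound 3 is therefore expected to reach about 85%, likely between 60% and 110%.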

Compound 3, largest response reached (reported as maximal response), in percent of the reference or control that the assay uses: 57%
Estimate against measurement, compound 3: 28 percentage points above; the measured number lies below the stated range.
By their numbers in this assay, from the lowest: compounds 3 and 1 (each within the scatter of the next); then compound 2.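

In this assay, nearly all of the change at this place already appears with the propyl chain: lengthening methyl to propyl gives a number 59 percentage points lower from compound 2 to compound 3 (beyond the scatter), whereas shortening butyl to propyl gives a number 9 percentage points lower from compound 1 to compound 3 (within the scatter). Among these three compounds, then, the response does not simply track chain length: the methyl compound stands apart, and the propyl and butyl compounds cannot be told apart. No measurement shown here accounts for this behaviour.

Where the response falls between methyl and propyl remains open, and an ethyl chain, which lies between the two in length, would address that. Also open, from the compounds shown here alone, is whether a branched isopropyl group or a chain ending in a hydroxyl group would behave like the methyl compound or like the propyl and butyl compounds.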